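The source may report more compounds than this note shows. Statements on the series, on what has been measured and on what is new or still open speak of the compounds shown alone.

Compound 1 `CC1CC(=O)N(CC(=O)N2CCN(c3ccc(Cl)cc3)CC2)C1=O` is examined in a functional assay on the whole organism (strain CD1) with Mus musculus as the target, in the maximal electroshock model, with a stated time of 4 h (a higher number here means that more compound is needed for the effect, a lower number that less compound is needed), where compound 1 gives 30 mg/kg. For the measured compounds named here, this is the lowest of the two numbers known so far; compound 2 `CCC1(C)CC(=O)N(CC(=O)N2CCN(c3cccc(C(F)(F)F)c3)CC2)C1=O` gives 100 mg/kg in this assay, a higher number lying beyond the scatter. Compound 3 `CC1CC(=O)N(CC(=O)N2CCN(c3ccc(Cl)c(Cl)c3)CC2)C1=O` has not yet been tested. Compared with compound 1, compound 3 carries one change: chloro in place of hydrogen on an aromatic carbon. Going by the values given here, no measured pair shows this change, so the expectation rests on compound 1 alone. The step of no change at the digits printed from compound 1 to compound 3 (within the scatter) is expected to stay within the usual scatter. Compound 3 is therefore estimated at 30 mg/kg, with a range from 10 mg/kg to 100 mg/kg.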

Compound 3, minimum effective dose: 100 mg/kg
For compound 3 the middle estimate is 3.3-fold (0.52 log units) below the measured one; the measured number falls inside the stated range.
By their numbers in this assay, from the lowest: compound 1; then compounds 2 and 3 (each within the scatter of the next).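

The change from 4-chlorophenyl to 3,4-dichlorophenyl gives a 3.3-fold higher number from compound 1 to compound 3 (0.52 log units; beyond the scatter) in this assay, beyond the scatter. For the compounds shown here, this is the first measured pair to differ at this aromatic carbon, ortho to a chloro group, and it shows that a second chloro here is not neutral: more compound is needed for the effect. No available measurement explains this step.

From the compounds shown here alone, it remains open whether a fluoro, methyl or methoxy group at this carbon would give a similar step. A single pair also cannot show whether the step would carry over to another substituted phenyl compound.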